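The source may report more compounds than this note shows. Statements on the series, on what has been measured and on what is new or still open speak of the compounds shown alone.

Compound 1 `COc1ccc([C@@H]2C/C(=N/OCc3cn(-c4ccc(O)cc4)nn3)c3cc(CC=C(C)C)c(OC)cc3O2)cc1` was tested in a functional assay on A549 cells (Homo sapiens) for inhibition, read by sulforhodamine B assay, with a stated time of 48 h, tested at 50 uM (on this read-out higher numbers stand for more inhibition of growth at the one concentration tested and lower numbers for less inhibition of growth), where compound 1 gives 52%. Among the three measured compounds this is the lowest number. Compound 3 `COc1cc2c(cc1CC=C(C)C)C(=O)C[C@@H](c1ccc(Oc3ccc(Br)cc3)cc1)O2` in this assay gives 72%, a number beyond the scatter above that of compound 1, and compound 2 `COc1cc2c(cc1CC1OC1(C)C)C(=O)C[C@@H](c1ccc(O)cc1)O2` in this assay gives 79%, which also lies beyond the scatter above compound 1.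

Compound 4 `COc1ccc([C@@H]2C/C(=N/OCc3cn(-c4cccnc4Cl)nn3)c3cc(CC=C(C)C)c(OC)cc3O2)cc1` has not yet been measured. It differs from compound 1 in one place: 2-chloropyridin-3-yl in place of 4-hydroxyphenyl on an aromatic nitrogen. Cut one bond further out, the same difference reads 1-(4-hydroxyphenyl)-1H-1,2,3-triazol-4-yl to 1-(2-chloropyridin-3-yl)-1H-1,2,3-triazol-4-yl. Going by the values given here, no pair among the measured compounds differs in only this one place, so the measured numbers give no direct guide to the size of this step.

The step of a number 3 percentage points higher from compound 1 to compound 4 (within the scatter) is expected to be small, within the scatter or only slightly upward. Compound 4 is therefore estimated at 55% in this assay, with a range from 35% to 75%.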

Compound 4, percent growth inhibition at one concentration: 58%
Compound 4: middle estimate off by 3 percentage points, on the low side; measured number inside the range.
By their numbers in this assay, from the lowest: compounds 1 and 4 (each within the scatter of the next); then compounds 3 and 2 (each within the scatter of the next).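

In this assay, putting 2-chloropyridin-3-yl in place of 4-hydroxyphenyl on the aromatic nitrogen amounts to a number 6 percentage points higher from compound 1 to compound 4 (within the scatter). This first look at the position shows that two quite different six-membered aromatic rings can sit there without a change beyond the scatter, and that the hydrogen-bond donor of the 4-hydroxyphenyl group is not required to keep the growth inhibition seen at this one concentration. The data at hand offer no explanation for this tolerance.

This single pair cannot separate the loss of the hydroxyl group from the entry of the ring nitrogen and the chlorine. On these data alone, it also remains open whether an unsubstituted phenyl ring, a carboxylic acid on the ring or a plain alkyl chain on the same nitrogen would shift the number.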